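The source may hold more compounds than are shown below. What is called first, only, known or untested is meant among the compounds shown, and "the series" means these compounds.

Measured compounds:

Compound 1, `CC(C)NC(=O)c1cc(-c2ccc(Cl)cc2Cl)n[nH]1`, 51 nM
Compound 2, `CC(C)(C)NC(=O)c1cc(-c2ccc(Cl)cc2Cl)n[nH]1`, 398 nM
Compound 3, `CN1CCN(C(=O)c2cc(-c3ccc(Cl)cc3Cl)n[nH]2)CC1`, 828 nM

All three share one core and differ only in the group attached to the carbonyl carbon. In an assay on isolated protein for inhibition of alkaline phosphatase, tissue-nonspecific isozyme (Homo sapiens) (on this read-out higher numbers stand for weaker inhibition and lower numbers for stronger inhibition), compound 1 gives 51 nM, compound 2 gives 398 nM and compound 3 gives 828 nM. Compound 3 therefore stands at the weakest end of the three: the step of a 16-fold higher number from compound 1 to compound 3 (1.21 log units; beyond the scatter) is large, and the step of a 2.1-fold higher number from compound 2 to compound 3 (0.32 log units; beyond the scatter) is modest, so compound 3 inhibits less strongly than either open-chain amide.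

Compound 4, `O=C(c1cc(-c2ccc(Cl)cc2Cl)n[nH]1)N1CCOCC1`, has not yet been measured. Its change from compound 3 is morpholin-4-yl in place of 4-methylpiperazin-1-yl on a carbonyl carbon. For the measured compounds named here, the measured steps bear on it only loosely: the steps of a 7.8-fold higher number from compound 1 to compound 2 (0.89 log units; beyond the scatter) and a 2.1-fold higher number from compound 2 to compound 3 (0.32 log units; beyond the scatter) show that enlarging or ring-closing the amide group has raised the number each time, but no measured pair swaps one six-membered ring for another. Compound 4 keeps a ring of the same size and the same count of acceptors, so in this assay compound 4 is expected to land near compound 3, with a step of a 1.2-fold higher number from compound 3 to compound 4 (0.08 log units; within the scatter) that may not stand out from the scatter. The estimate for compound 4 is 1000 nM, within a range from 300 nM to 3500 nM.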

Compound 4, half-maximal inhibitory concentration: 574 nM
Estimate against measurement, compound 4: 1.7-fold (0.24 log units) above; the range from low to high includes it.
By their numbers in this assay, from the lowest: compound 1; then compounds 2, 4 and 3 (each within the scatter of the next, the first and the last beyond it).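

In this assay, exchanging one six-membered ring for another on the carbonyl carbon gives a 1.4-fold lower number from compound 3 to compound 4 (0.16 log units; within the scatter), so this swap of 4-methylpiperazin-1-yl for morpholin-4-yl cannot be told apart from repeat-measurement noise. Morpholin-4-yl and the open-chain (tert-butyl)amino group cannot be separated either, with a 1.4-fold higher number from compound 2 to compound 4 (0.16 log units; within the scatter), whereas isopropylamino stays clearly apart from the new ring, with an 11-fold higher number from compound 1 to compound 4 (1.05 log units; beyond the scatter), which shows that the large gap from compound 1 is not peculiar to the 4-methylpiperazin-1-yl ring and leaves compound 1 the strongest inhibitor of the four. No measurement here explains why these groups compare as they do.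

The compounds shown leave open whether a shorter chain such as ethylamino would match isopropylamino, and whether piperidin-1-yl, a six-membered ring with no second hetero atom, would sit with the two rings tested here. They also leave open whether a small ring that keeps the amide hydrogen, such as cyclopropylamino, would behave like isopropylamino or like the two rings on the carbonyl carbon.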